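Swapping the acid for a methyl sulfone on the side chain

This account rests on a few compounds, and the source may have more. Where it says the series, first, only, none or still open, it means among the compounds named here.

Compound 2 `O=C(O)CCc1nc(Nc2ccc(C(F)(F)F)cc2)c2ccc(-c3ncccc3C(F)(F)F)cc2n1` carries a carboxy group at the end of its side chain. Within the data shown here, in a functional assay for antagonist activity at transient receptor potential cation channel subfamily V member 1 (Homo sapiens) (a lower number here means a stronger inhibitor, a higher number a weaker inhibitor), compound 2 gives 1630 nM, the highest of the two numbers measured so far. Among the measured compounds shown here, its only neighbour is compound 1 `OCCCc1nc(Nc2ccc(C(F)(F)F)cc2)c2ccc(-c3ncccc3C(F)(F)F)cc2n1`, which in this assay gives 25 nM; that step is a 65-fold higher number from compound 1 to compound 2 (1.81 log units; beyond the scatter).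

Compound 3 `CS(=O)(=O)CCc1nc(Nc2ccc(C(F)(F)F)cc2)c2ccc(-c3ncccc3C(F)(F)F)cc2n1` is not yet measured. It differs from compound 2 by methylsulfonyl in place of carboxy on a saturated chain carbon, two bonds along the chain from an aromatic carbon. For the measured compounds named here, the one measured step bears on it only indirectly: it shows that the carboxy group of compound 2 goes with a much weaker result than the hydroxymethyl group of compound 1, so removing the carboxy group is expected to move the number back down, though probably not all the way. The step from compound 2 to compound 3 in this assay is estimated at an 11-fold lower number from compound 2 to compound 3 (1.04 log units; beyond the scatter). Compound 3 is therefore expected to give 150 nM, within a range of 40 nM to 600 nM.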

Compound 3, half-maximal inhibitory concentration in the transient receptor potential cation channel subfamily V member 1 assay: 36 nM
Compound 3: the middle estimate sits 4.2-fold (0.62 log units) above what was measured; the whole stated range lies above it.
By their numbers in the transient receptor potential cation channel subfamily V member 1 assay, from the lowest: compounds 1 and 3 (each within the scatter of the next); then compound 2.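

At this chain position, the weak result in the transient receptor potential cation channel subfamily V member 1 assay goes with the carboxy group specifically, not with every replacement of hydroxymethyl: methylsulfonyl in its place gives a 45-fold lower number from compound 2 to compound 3 (1.66 log units; beyond the scatter). Methylsulfonyl and hydroxymethyl cannot be told apart here, with a 1.4-fold higher number from compound 1 to compound 3 (0.16 log units; within the scatter), so this position tolerates a group with 0 hydrogen-bond donors as well as compound 1 does with its hydroxymethyl. The same swap that recovers the result runs at a heavy price in a physicochemical assay for solubility, at pH 7.4 (a lower number here means a less soluble compound, a higher number a more soluble compound), where compound 2 gives 125 ug/mL and compound 3 gives 0.2 ug/mL: the measured solubility of compound 2, 125 ug/mL, and of compound 3, 0.2 ug/mL, a 630-fold lower number (2.80 log units; beyond the scatter)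

The compounds shown leave open whether another end group on this chain, such as an amine or a primary amide, could combine a low number in the transient receptor potential cation channel subfamily V member 1 assay with a high number in the physicochemical assay. They also leave open how a longer chain carrying methylsulfonyl would behave in either assay.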